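Methyl in place of acetyl on a sulfur

The source may hold more compounds than are shown below. What is called first, only, known or untested is meant among the compounds shown, and "the series" means these compounds.

Values in a functional assay on PC-3 cells (Homo sapiens) for inhibition, read by MTT assay, with a stated time of 96 h; a lower number here means a stronger inhibitor of growth, a higher number a weaker inhibitor of growth
- compound 1 `C=CCOC(=O)SCCCCCCNC(=O)c1cc(-c2ccncc2)n[nH]1` gives 24800 nM
- compound 2 `CCC(=O)SCCCCCCNC(=O)c1cc(-c2ccncc2)n[nH]1` gives > 50000 nM (a limit, not a number)
- compound 3 `CC(=O)SCCCCCCNC(=O)c1cc(-c2ccncc2)n[nH]1` gives 36000 nM

Within the data shown here, compound 3 lies within the scatter of compound 1, the only other compound with a number. Compound 2 stands at the limit (the limit of > 50000 nM in this assay, at which 1 of the 3 values shown sits).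

Compound 4 `CSCCCCCCNC(=O)c1cc(-c2ccncc2)n[nH]1` carries methyl in place of acetyl on a sulfur. The measured steps run a 1.5-fold higher number from compound 1 to compound 3 (0.16 log units; within the scatter) and an at least 2.0-fold higher number from compound 1 to compound 2 (0.30 log units; that floor lies within the scatter) and an at least 1.3-fold lower number from compound 2 to compound 3 (0.14 log units; that floor lies within the scatter) and none is shown beyond the scatter. All three change only the group on the carbonyl carbon, and none removes that carbonyl, so they are an indirect guide to this change. Their small size gives no ground for expecting a large step, and weak growth inhibition is expected to persist. The expected change is a 1.3-fold higher number from compound 3 to compound 4 (0.10 log units; within the scatter) and this lies within the scatter. A reading at the limit is quite possible. In this assay compound 4 is estimated at 45000 nM with an expected range of 18000 nM to 90000 nM for a numerical result.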

Compound 4, concentration for 50% growth inhibition: > 50000 nM
Compound 4: no number, only a limit (the forecaster's own chance of this, stated with the estimate: 55%); at least 1.1-fold (0.04 log units) between middle value and limit.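

In this assay compound 4 gives > 50000 nM, a limit and not a number. This is the only change shown that takes the carbonyl off the sulfur, and it reads as an at least 1.3-fold higher number from compound 3 to compound 4 (0.14 log units; that floor lies within the scatter) and as an at least 2.0-fold higher number from compound 1 to compound 4 (0.30 log units; that floor lies within the scatter); with both floors inside the scatter, the carbonyl is shown neither to be needed nor to be dispensable for the weak growth inhibition of compound 1 and compound 3. The step between compound 2 and compound 4 cannot be read, and compound 4 now joins compound 2 at the limit: the limit of > 50000 nM in this assay, at which 2 of the 4 values shown sit.

Open, going by these compounds, is how a free thiol or a carboxylic acid in place of the methylsulfanyl would read in this assay. Also open, on these data alone, is whether a longer chain would move any of these sulfur groups clearly beyond the scatter.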